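Methoxy for Bromo on the Carbonyl-Side Ring

The source may hold more compounds than are shown below. What is called first, only, known or untested is meant among the compounds shown, and "the series" means these compounds.

Compound 3 `O=C(/C=C/c1ccc(OCc2cn(Cc3cccc(F)c3)nn2)cc1)c1ccc(Br)cc1` stands highest of the three numbers in a functional assay on MCF7 cells (Homo sapiens) for inhibition, read by MTT assay, with a stated time of 48 h, tested at 10 uM (on this read-out lower numbers stand for less inhibition of growth and higher numbers for more inhibition of growth at the one concentration tested), where compound 3 gives 42%. Compound 2 `O=C(/C=C/c1ccc(OCc2cn(Cc3ccccc3F)nn2)cc1)c1ccc(Br)cc1` gives 38%, and compound 1 `O=C(/C=C/c1ccc(OCc2cn(Cc3ccc(Br)cc3)nn2)cc1)c1ccc(Br)cc1` gives 23%. Every measured step changes the ring on the saturated chain carbon bound to an aromatic nitrogen: a number 15 percentage points higher from compound 1 to compound 2 (beyond the scatter), a number 19 percentage points higher from compound 1 to compound 3 (beyond the scatter) and a number 4 percentage points higher from compound 2 to compound 3 (within the scatter). Compound 4 `COc1ccc(C(=O)/C=C/c2ccc(OCc3cn(Cc4cccc(F)c4)nn3)cc2)cc1` differs from compound 3 at another place: methoxy in place of bromo on an aromatic carbon. For the measured compounds named here, no measured step touches that place, so the three steps offer no direct guide, and a step of no size beyond the scatter is the plainest expectation in this assay. Compound 4 is therefore estimated at 42%, with a range from 22% to 62%, an expected step of no change at the digits printed from compound 3 to compound 4 (within the scatter).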

Compound 4, percent growth inhibition at one concentration: 41%
For compound 4 the middle estimate is 1 percentage points above the measured one; low and high end bracket the measured number.
By their numbers in this assay, from the lowest: compound 1; then compounds 2, 4 and 3 (each within the scatter of the next).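

In this assay, methoxy in place of bromo on an aromatic carbon gives a number 1 percentage points lower from compound 3 to compound 4 (within the scatter). For the compounds shown here, this is the first reading at this place on the carbonyl-side ring, and it shows that 4-methoxyphenyl and 4-bromophenyl cannot be told apart there when the 3-fluorophenyl group is held fixed. Nothing available explains why the two groups read alike. Going by these compounds, it remains open how an amine, a carboxylic acid or a longer chain would read at this place, and whether the same exchange would read alike alongside the rings of compound 1 or compound 2.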